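Methylation of the ring hydroxy group across two cores

A few compounds are considered here, and "the series" means these few. Any claim that something is new, unique, unknown or untested is made for them only; others in the source may bear on it.

Measured so far in a physicochemical assay for lipophilicity; a lower number here means a more polar compound, a higher number a more lipophilic compound:
- compound 1, `CN(C)c1ccc(-c2nc3ccc(O)cc3s2)cn1`: 2.4
- compound 2, `COc1ccc2nc(-c3ccc(N(C)C)nc3)sc2c1`: 4.2
- compound 3, `CNc1ccc(-c2cc3ccc(O)cc3o2)cn1`: 2

Compound 2 differs from compound 1 by methyl in place of hydrogen on an oxygen on an aromatic ring; this step reads a number 1.80 log units higher from compound 1 to compound 2 (beyond the scatter). Compound 3 has the lowest number of the three, and the difference between its core and the core of compound 1 is not broken down here.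

Compound 4, `CNc1ccc(-c2cc3ccc(OC)cc3o2)cn1`, is not yet measured. It differs from compound 3 by methyl in place of hydrogen on an oxygen on an aromatic ring. The place of this change is the same in wording as the place of the change from compound 1 to compound 2, so it is the same change, made here on the core of compound 3 rather than on the core of compound 1.

Set beside the measured step from compound 1 to compound 2, the step from compound 3 to compound 4 is expected to come out as a number 1.60 log units higher from compound 3 to compound 4 (beyond the scatter), resting on the single measured instance of this change, which is a number 1.80 log units higher from compound 1 to compound 2 (beyond the scatter). The estimate for compound 4 in this assay is therefore 3.6, expected to lie between 3 and 4.2.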

Compound 4, distribution coefficient: 3.8
For compound 4 the middle estimate is 0.20 log units below the measured one, and the stated range covers the measured number.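

In this assay the hydroxy to methoxy change reads a number 1.80 log units higher from compound 3 to compound 4 (beyond the scatter) and also a number 1.80 log units higher from compound 1 to compound 2 (beyond the scatter) on a different core, so the step has the same size in both pairs. This shows that the change carried from one core to the other without any shift in its size, but two pairs on two cores give no rule for other cores in the series. Nothing available here explains the size of the step or why it matches, so the agreement stands as an observation only.

Still open, from the compounds shown here alone, is whether a longer chain on that oxygen, such as ethyl or propyl in place of methyl, would give a step of similar size, and whether the methyl step would hold on a third core. Going by these compounds, an amine or a carboxylic acid in place of the hydroxy group on the aromatic ring is equally open.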